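Aryl substituent step: 2-fluorophenyl to 2-vinylphenyl

The compounds below may be only part of what the source reports. "The series", "measured", "known", "first", "only" and "open" are said of these compounds alone.

Values so far in a functional assay (muscle tissue) with Cavia porcellus as the target (on this read-out higher numbers stand for an effect only at larger amounts of compound and lower numbers for an effect already at smaller amounts), are these
- compound 1 `COC(=O)C1=C(C)N=C(C)/C(=C(\O)OC)C1c1ccc(Cl)cc1` gives 8130 nM
- compound 2 `COC(=O)C1=C(C)N=C(C)/C(=C(\O)OC)C1c1cccc(O)c1` gives 1000 nM
- compound 3 `COC(=O)C1=C(C)N=C(C)/C(=C(\O)OC)C1c1ccccc1F` gives 42.7 nM

Compound 3 has the lowest number of the three, set apart by a 23-fold lower number from compound 2 to compound 3 (1.37 log units; beyond the scatter) and by a 190-fold lower number from compound 1 to compound 3 (2.28 log units; beyond the scatter) in the same read-out. Compound 4 `C=Cc1ccccc1C1C(C(=O)OC)=C(C)N=C(C)/C1=C(\O)OC` carries vinyl in place of fluoro on an aromatic carbon, ortho to a large group (vinyl in place of fluoro on an aromatic carbon). For the measured compounds named here, no measured step makes this exchange. The two large steps above change the aryl group more broadly and bear on it only indirectly, while 2-fluorophenyl to 2-vinylphenyl is a smaller change. In this assay the expected step is a 1.6-fold higher number from compound 3 to compound 4 (0.21 log units; within the scatter) and so stays small, leaning upward. For compound 4 the estimated value is 70 nM within an expected range of 18 nM to 270 nM for now.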

Compound 4, half-maximal effective concentration: 4.47 nM
The estimate for compound 4 lay 16-fold (1.19 log units) above the measured number, and the stated range ends above it.
By their numbers in this assay, from the lowest: compound 4; then compound 3; then compound 2; then compound 1.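

In this assay, for the compounds shown here, the exchange of fluoro for vinyl, ortho to a large group, gives a 9.6-fold lower number from compound 3 to compound 4 (0.98 log units; beyond the scatter) as a step beyond the scatter, so this place on the aryl ring accepts vinyl and the lowest number of the earlier compounds was not a floor. The wider aryl exchanges, a 220-fold lower number from compound 2 to compound 4 (2.35 log units; beyond the scatter) and a 1800-fold lower number from compound 1 to compound 4 (3.26 log units; beyond the scatter), now span the whole series, with compound 4 lowest of the four. No available evidence accounts for the step.

Open, from the compounds shown here alone, is whether the double bond itself matters or simply the longer substituent. An ethyl group or a longer chain at this place, or an amine, would help separate these readings.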